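From 4-ethylphenyl to 3,5-dimethylphenyl on a sulfonamide nitrogen

A few compounds are considered here, and "the series" means these few. Any claim that something is new, unique, unknown or untested is made for them only; others in the source may bear on it.

Measured in a functional assay on MCF7 cells (Homo sapiens) for antiproliferative activity, read by sulforhodamine B assay, with a stated time of 48 h (a higher number here means a weaker inhibitor, a lower number a stronger inhibitor), so far:
- compound 1 (`CCc1ccc(NS(=O)(=O)c2ccc(N3CCNC3=O)cc2)cc1`) gives 810 nM
- compound 2 (`CC(C)(C)c1ccc(NS(=O)(=O)c2ccc(N3CCNC3=O)cc2)cc1`) gives only a limit (> 1000 nM)

Within the data shown here, compound 1 thus holds the only true number (810 nM) in this assay so far. Compound 3 (`Cc1cc(C)cc(NS(=O)(=O)c2ccc(N3CCNC3=O)cc2)c1`) keeps the core of compound 1 and carries 3,5-dimethylphenyl in place of 4-ethylphenyl on a sulfonamide nitrogen. Among the measured compounds shown here, the one measured step (an at least 1.2-fold higher number from compound 1 to compound 2 (0.09 log units; that floor lies within the scatter)) puts tert-butyl in place of ethyl on an aromatic carbon, gives only a floor within the scatter, and so suggests no size for this change. No step beyond the scatter is therefore expected (a 1.0-fold lower number from compound 1 to compound 3 (0.01 log units; within the scatter)). Compound 3 is estimated at 800 nM (250 nM to 2500 nM).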

Compound 3, half-maximal inhibitory concentration: 100 nM
For compound 3 the middle estimate is 8.0-fold (0.90 log units) above the measured one, outside the stated range (below it).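

In this assay, the group on the sulfonamide nitrogen moved the read-out beyond the scatter, with an 8.1-fold lower number from compound 1 to compound 3 (0.91 log units; beyond the scatter). The two groups have the same heavy atoms and the same counts, so the arrangement of those carbons alone separates compound 1 and compound 3, which the earlier pair could not show. Compound 2 remains a limit and not a number: the limit of > 1000 nM in this assay, at which 1 of the 3 values shown sits.

Going by these compounds, whether a single methyl on the phenyl ring would give the same result remains open. So does the outcome with a methoxy, an amine or a carboxylic acid in place of the two methyl groups.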